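The source may hold more compounds than are shown below. What is called first, only, known or untested is meant among the compounds shown, and "the series" means these compounds.

Working notes on the series.

Two members of the series have been measured in a functional assay on SK-MEL-2 cells (Homo sapiens) for inhibition, read by sulforhodamine B assay, with a stated time of 48 h, tested at 10 uM; a lower number here means less inhibition, a higher number more inhibition at the concentration tested (going by the name of the read-out). Compound 1, `c1ccc2c(-c3cn4ccnc4c(-c4ccc5ncn(C6CCCCC6)c5c4)n3)cccc2c1`, gives 2.3% in this assay. Compound 2, `CC(=O)c1ccc(-c2cn3ccnc3c(-c3ccc4ncn(C5CCCCC5)c4c3)n2)cc1`, gives 0.58% in this assay. For the measured compounds named here, the single measured step, a number 1.7 percentage points lower from compound 1 to compound 2 (within the scatter), is within the scatter, so the two numbers cannot be ordered against each other, and compound 2 simply stands at the lower of the two readings with compound 1 close by.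

Compound 3, `Brc1ccc(-c2cn3ccnc3c(-c3ccc4ncn(C5CCCCC5)c4c3)n2)cc1`, has not been measured in this assay. It differs from compound 2 by bromo in place of acetyl on an aromatic carbon, which, cut one bond further out, reads 4-acetylphenyl to 4-bromophenyl. Going by the values given here, no measured step touches this position in the same way. Among the compounds with values here, the only step available, from 1 to 2, exchanged a 4-acetylphenyl for a naphthalen-1-yl and moved the reading by an amount within the scatter, so it gives no ground for expecting a step beyond the scatter here either.

For compound 3 a step of a number 0.9 percentage points higher from compound 2 to compound 3 (within the scatter) is expected, meaning no change beyond the scatter. Compound 3 is therefore estimated at 1.5%, with a range from -4% to 9%.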

Compound 3, a percentage reported as inhibition, at one concentration (the size of the read-out at that concentration, not a potency): 24.1%
Beside the measured number, compound 3's estimate is 22.6 percentage points below it, outside the stated range (above it).
By their numbers in this assay, from the lowest: compounds 2 and 1 (each within the scatter of the next); then compound 3.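

The position para to a large group is not indifferent to its substituent in this assay: bromo in place of acetyl on an aromatic carbon gives a number 23.5 percentage points higher from compound 2 to compound 3 (beyond the scatter), and 4-bromophenyl in place of naphthalen-1-yl gives a number 21.8 percentage points higher from compound 1 to compound 3 (beyond the scatter). The earlier pair showed only a step within the scatter, which could have been read as a flat position, whereas these two steps show that the reading depends on which group is carried there, and that 4-bromophenyl stands apart from both 4-acetylphenyl and naphthalen-1-yl, although the steps are modest and the reading comes from one concentration, so it says nothing about potency. The compounds shown offer nothing that accounts for this separation, so the step stands as an observation without an explanation.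

From the compounds shown here alone, it remains open whether the higher reading is specific to bromo or would also appear with another small group in the same place, such as chloro, methyl or methoxy. An amine or a carboxylic acid at this position, and any replacement of the cyclohexyl group elsewhere on the shared core, also remain to be placed against compound 3.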